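A few compounds are considered here, and "the series" means these few. Any claim that something is new, unique, unknown or untested is made for them only; others in the source may bear on it.

Measured compounds:
compound 1 `COc1cc2c(cc1OC)C(CC(=O)NC(C)(C)C)CC2` — 40%
compound 2 `COc1cc2c(cc1OC)C(CC(=O)N1CCCC1)CC2` — 33.3%

In a functional assay on the whole organism (strain Wistar) for inhibition, with Rattus norvegicus as the target, read by paw edema, with stated times of 60 min and 24 h, at a dose of 100 mg/kg by the oral route (a lower number here means less inhibition, a higher number more inhibition at the dose given (going by the name of the read-out)), compound 1 gives 40% and compound 2 gives 33.3%. Compound 2 has the lower of the two numbers, but the gap to compound 1, a number 6.7 percentage points lower from compound 1 to compound 2 (within the scatter), lies within the scatter, so the two compounds cannot be told apart on these readings.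

Compound 3 `COc1cc2c(cc1OC)C(CC(=O)NCCO)CC2` has not yet been measured. It differs from compound 2 at the carbonyl carbon: (2-hydroxyethyl)amino in place of pyrrolidin-1-yl on a carbonyl carbon.

Going by the values given here, the only measured step that bears on this change is the exchange of groups on the same carbonyl carbon, a number 6.7 percentage points lower from compound 1 to compound 2 (within the scatter), which was within the scatter. One such step gives no reason to expect a change beyond the scatter here either. Compound 3 is therefore expected to give about 35% in this assay, with a range from 20% to 50%; the expected step is a number 1.7 percentage points higher from compound 2 to compound 3 (within the scatter).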

Compound 3, a percentage reported as inhibition, in the whole organism at one dose (the size of the read-out at that dose, not a potency): 13.3%
The estimate for compound 3 lay 21.7 percentage points above the measured number; the whole stated range lies above it.
By their numbers in this assay, from the lowest: compound 3; then compounds 2 and 1 (each within the scatter of the next).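

In this assay, the group on the carbonyl carbon now proves able to move the number: the change to (2-hydroxyethyl)amino gives a number 20 percentage points lower from compound 2 to compound 3 (beyond the scatter) and so goes beyond the scatter, which the earlier exchange at this place did not. Measured against the tert-butyl amide, the change of 2-hydroxyethyl for tert-butyl on the amide-type nitrogen gives a number 26.7 percentage points lower from compound 1 to compound 3 (beyond the scatter) and also goes beyond the scatter, so compound 3 stands apart from both earlier compounds. Nothing measured here accounts for this drop.

The compounds shown leave open whether the oxygen of the 2-hydroxyethyl group goes with the lower number, which an ethyl or 2-methoxyethyl group on the same nitrogen would test. They also leave open how a longer chain such as 3-hydroxypropyl, or a carboxylic acid at the end of the chain, would read.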